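This account rests on a few compounds, and the source may have more. Where it says the series, first, only, none or still open, it means among the compounds named here.

Measured compounds:
- compound 1 `CCCCc1ccc(CNC(=O)NC2CCCCC2)c(=O)n1Cc1ccc(-c2ccccc2-c2nn[nH]n2)cc1`: 90 nM
- compound 2 `CCCCc1ccc(CNS(=O)(=O)c2ccc(C)cc2)c(=O)n1Cc1ccc(-c2ccccc2-c2nn[nH]n2)cc1`: 9 nM

Both compounds share one core and differ only at the group on the amine nitrogen. In a functional assay (aorta) for antagonist activity, with Oryctolagus cuniculus as the target (a lower number here means a stronger inhibitor, a higher number a weaker inhibitor), compound 1 gives 90 nM, and compound 2 gives 9 nM. Among the compounds with values here, the one step measured so far, a 10-fold lower number from compound 1 to compound 2 (1.00 log units; beyond the scatter), goes with the exchange of the cyclohexylcarbamoyl group for the (4-methylphenyl)sulfonyl group. Compound 2 thus stands with the lowest of the two numbers, and its nearest neighbour, compound 1, lies above it by more than the scatter.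

Compound 3 `CCCCc1ccc(CN(CC)S(C)(=O)=O)c(=O)n1Cc1ccc(-c2ccccc2-c2nn[nH]n2)cc1` takes the change (ethyl(methylsulfonyl)amino in place of ((4-methylphenyl)sulfonyl)amino on a saturated chain carbon bound to an aromatic carbon). Within the data shown here, no measured step covers this exchange: the one step in hand only tells that a sulfonyl group on that nitrogen did better than a carbamoyl group, and it says nothing about removing the aromatic ring, shortening the sulfonyl part to methyl, or replacing the hydrogen on the nitrogen with ethyl. Because a 10-fold lower number from compound 1 to compound 2 (1.00 log units; beyond the scatter) does not reach the new change, the expectation rests on the size of what is removed: compound 3 is expected to give a somewhat higher number, a 4.4-fold higher number from compound 2 to compound 3 (0.65 log units; beyond the scatter), in this assay. For compound 3 the estimate is 40 nM, with a likely range from 9 nM to 250 nM.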

Compound 3, half-maximal inhibitory concentration: 2 nM
Compound 3: the middle estimate sits 20-fold (1.30 log units) above what was measured; the measured number lies below the stated range.
By their numbers in this assay, from the lowest: compound 3; then compound 2; then compound 1.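

In this assay, the ring of the ((4-methylphenyl)sulfonyl)amino group proves unnecessary for a low number at this place: the smaller, ring-free ethyl(methylsulfonyl)amino group, which also has no hydrogen-bond donor, goes with a 4.5-fold lower number from compound 2 to compound 3 (0.65 log units; beyond the scatter) rather than with any loss. Set against the (cyclohexylcarbamoyl)amino group, the same exchange goes with a 45-fold lower number from compound 1 to compound 3 (1.65 log units; beyond the scatter) and is the largest step so far, so both sulfonyl compounds now sit below the carbamoyl compound, even though their groups differ in size, in the ring and in the hydrogen on the nitrogen. No other measurement here offers an explanation for this gain.

Compound 3 differs from compound 2 in several features at once, so the compounds shown cannot assign the gain to the ethyl on the nitrogen, the methyl on the sulfonyl or the loss of the ring; a methylsulfonylamino group that keeps the hydrogen on the nitrogen would begin to separate these features. Also open, from the compounds shown here alone, is how a longer chain on that nitrogen, such as propyl or butyl, would behave with the methylsulfonyl group kept in place.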